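This account rests on a few compounds, and the source may have more. Where it says the series, first, only, none or still open, it means among the compounds named here.

Compound 1, `CCCCCCCCOc1nc(N)nc2c1ncn2/C=C1/CC1(CO)CO`, and compound 2, `CCCCSc1nc(N)nc2c1ncn2/C=C1/CC1(CO)CO`, share one core and were both tested in an ADME assay on HFF cells (Homo sapiens) for cytotoxicity, with a stated time of 8 days; on this read-out higher numbers stand for lower toxicity in this test and lower numbers for higher toxicity in this test. In this assay compound 1 gives > 300000 nM, which is a limit of the assay rather than a number. Compound 2 likewise gives > 300000 nM, again a limit and not a number. The step that the two limits leave unreadable from compound 1 to compound 2 is therefore unreadable, since (the limit of > 300000 nM in this assay, at which 2 of the 2 values shown sit). Compound 2 thus stands at the edge of what this assay can report. Compound 3, `Nc1nc(NC2CCCCC2)c2ncn(/C=C3/CC3(CO)CO)c2n1`, differs from compound 2 by cyclohexylamino in place of butylsulfanyl on an aromatic carbon. Going by the values given here, the only measured step concerns a different change and its size cannot be read, so it gives no direction for this one; nothing beyond the scatter is expected. Compound 3 is therefore estimated at 300000 nM, within 100000 nM to 600000 nM. This estimate means an expected step of a number no higher from compound 2 to compound 3 (the limit leaves the size open).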

Compound 3, half-maximal cytotoxic concentration: > 300000 nM
Compound 3 ended at the assay's limit; the forecaster's own chance of this, stated with the estimate: 75%; the middle value lies on the limit itself.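

In this assay compound 3 gives > 300000 nM, again a limit and not a number. Going by these compounds alone, no step among compound 1, compound 2 and compound 3 can therefore be read: the limit of > 300000 nM in this assay, at which 3 of the 3 values shown sit. The compounds shown leave open whether swapping these groups on the aromatic carbon changes cytotoxicity at all, and by how much.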